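Swapping 2-methoxyphenyl for furan-2-yl on a shared core

The compounds below may be only part of what the source reports. "The series", "measured", "known", "first", "only" and "open" are said of these compounds alone.

Of the compounds shown here, three with the same core have been tested so far, and they differ only in one group. In a functional assay on MCF7 cells (Homo sapiens) for cytotoxicity, read by MTT assay, with a stated time of 72 h (on this read-out lower numbers stand for stronger inhibition and higher numbers for weaker inhibition), compound 1 (`O=C1C(=Cc2ccc(O)cc2)C(=O)N(c2ccc(Cl)cc2)N1c1ccc(Cl)cc1`) gives 23200 nM. Compound 2 (`COc1cccc(C=C2C(=O)N(c3ccc(Cl)cc3)N(c3ccc(Cl)cc3)C2=O)c1`) gives 18100 nM, and compound 3 (`COc1ccccc1C=C1C(=O)N(c2ccc(Cl)cc2)N(c2ccc(Cl)cc2)C1=O`) gives 26300 nM. Compound 3 therefore stands level with the other two, since its gaps to both lie within the scatter of repeated measurements.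

Compound 4 (`O=C1C(=Cc2ccco2)C(=O)N(c2ccc(Cl)cc2)N1c1ccc(Cl)cc1`) has furan-2-yl in place of 2-methoxyphenyl on a double-bonded chain carbon bound to a double-bonded ring carbon.

The three measured steps all change this same place, so they are the relevant guide. They are a 1.3-fold lower number from compound 1 to compound 2 (0.11 log units; within the scatter), a 1.1-fold higher number from compound 1 to compound 3 (0.05 log units; within the scatter) and a 1.5-fold higher number from compound 2 to compound 3 (0.16 log units; within the scatter). All three are small, but none of them tests a furan-2-yl group, so the guidance is indirect. A five-membered ring could still behave differently from the six-membered rings tested so far. Even so, no step beyond the scatter is expected in this assay, in either direction. The estimated step is a 1.3-fold lower number from compound 3 to compound 4 (0.10 log units; within the scatter). For compound 4 the expected value is 21000 nM, with an estimated range from 10000 nM to 45000 nM.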

Compound 4, half-maximal inhibitory concentration: 20300 nM
Beside the measured number, compound 4's estimate is 1.0-fold (0.01 log units) above it, within the range that was stated.
By their numbers in this assay, from the lowest: compounds 2, 4, 1 and 3 (each within the scatter of the next).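

In this assay the place on the double-bonded chain carbon bound to a double-bonded ring carbon now holds a five-membered aromatic ring with a hetero atom, and furan-2-yl gives a 1.3-fold lower number from compound 3 to compound 4 (0.11 log units; within the scatter) and a 1.1-fold higher number from compound 2 to compound 4 (0.05 log units; within the scatter) and also a 1.1-fold lower number from compound 1 to compound 4 (0.06 log units; within the scatter) without any step leaving the usual spread of repeat measurements. The earlier compounds only varied the group carried on a six-membered aromatic ring of carbon, whereas this change replaces that ring itself and goes from 8 heavy atoms in 2-methoxyphenyl to 5 heavy atoms in furan-2-yl, so among these four compounds neither the ring type nor this drop in size separates the numbers. Nothing available here explains why the numbers stay so close.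

From the compounds shown here alone, all four compounds keep an aromatic ring at this place, so it remains open what a group without one, such as a cyclohexyl ring, a longer alkyl chain or a carboxylic acid, would do. Going by these compounds, a nitrogen-containing aromatic ring such as pyridine, or an amine on the phenyl ring, is equally open, as is any change to the shared core itself.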